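Phenyl for methylpyrrolyl on the amide-bound carbon

The compounds below may be only part of what the source reports. "The series", "measured", "known", "first", "only" and "open" are said of these compounds alone.

Compound 1 `CCN(Cc1cc[nH]c1)C(=O)COc1ccc(C)cc1`, in an assay on HEK293 cells for agonist activity at transient receptor potential cation channel subfamily M member 8 (Homo sapiens), read by fluorescence and calcium flux, with a stated time of 15 min (on this read-out lower numbers stand for an effect already at smaller amounts and higher numbers for an effect only at larger amounts of compound), compound 1 gives 21800 nM.
Compound 2 `CCN(Cc1cccn1C)C(=O)COc1ccc(C)cc1`, in this assay compound 2 gives 21300 nM.

Compound 2 and compound 1 sit at the same level: the step of a 1.0-fold lower number from compound 1 to compound 2 (0.01 log units; within the scatter) lies within the scatter, so the two numbers cannot be ordered. That step exchanged one five-membered ring for another on the saturated chain carbon bound to the amide-type nitrogen and left the read-out unchanged.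

Compound 3 `CCN(Cc1ccccc1)C(=O)COc1ccc(C)cc1` carries phenyl in place of 1-methyl-1H-pyrrol-2-yl on a saturated chain carbon bound to an amide-type nitrogen. Within the data shown here, the only measured step that bears on this change is the ring exchange from compound 1 to compound 2 at the same place, and it was a 1.0-fold lower number from compound 1 to compound 2 (0.01 log units; within the scatter), within the scatter. On that basis the expected step from compound 2 to compound 3 in this assay is a 1.1-fold lower number from compound 2 to compound 3 (0.03 log units; within the scatter), no change beyond the scatter. Compound 3 is therefore estimated at 20000 nM, with a range from 8000 nM to 50000 nM.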

Compound 3, half-maximal effective concentration: 1880 nM
For compound 3 the middle estimate is 11-fold (1.03 log units) above the measured one, outside the stated range (below it).
By their numbers in this assay, from the lowest: compound 3; then compounds 2 and 1 (each within the scatter of the next).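

At the saturated chain carbon bound to an amide-type nitrogen, the identity of the ring does matter in this assay: phenyl in place of 1-methyl-1H-pyrrol-2-yl gives an 11-fold lower number from compound 2 to compound 3 (1.05 log units; beyond the scatter) and phenyl in place of 1H-pyrrol-3-yl gives a 12-fold lower number from compound 1 to compound 3 (1.06 log units; beyond the scatter) even though the exchange between the two five-membered rings had shown no effect. Heavy-atom count is unchanged from 1-methyl-1H-pyrrol-2-yl to phenyl, so in that step the lower number goes with the ring exchange and not with the count of heavy atoms. Nothing measured here accounts for the lower number.

As far as these compounds go, whether it requires a ring of carbon only or simply a six-membered aromatic ring remains open, and pyridin-2-yl at this place would separate the two. Also open, from the compounds shown here alone, is whether a fluoro or methoxy group on the phenyl ring would shift the number further.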